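The compounds below may be only part of what the source reports. "The series", "measured", "known", "first", "only" and "open" are said of these compounds alone.

Compound 1 `Cc1cc(NC(=O)C(C)(O)C(F)(F)F)ccc1S(=O)(=O)c1ccccc1` and compound 2 `Cc1cccc(S(=O)(=O)c2ccc(NC(=O)C(C)(O)C(F)(F)F)cc2)c1` are built from the same atoms joined differently; the difference between their two cores is not broken down here. In a functional assay (Cavia porcellus) with sulfonylurea receptors; K-ATP channels (Homo sapiens) as the target (on this read-out higher numbers stand for weaker inhibition and lower numbers for stronger inhibition), compound 1 gives 1600 nM, and compound 2 gives 2200 nM, two numbers that lie within the usual scatter of each other. Compound 3 `CC(O)(C(=O)Nc1ccc(S(=O)(=O)c2ccccc2)c(C(F)(F)F)c1)C(F)(F)F` differs from compound 1 by trifluoromethyl in place of methyl on an aromatic carbon. Compound 3 reaches only a limit of this assay, > 30000 nM, as the limit of > 30000 nM in this assay, at which 1 of the 3 values shown sits, records. That change produced an at least 18-fold higher number from compound 1 to compound 3 (1.27 log units; beyond the scatter). Compound 4 `CC(O)(C(=O)Nc1ccc(S(=O)(=O)c2cccc(C(F)(F)F)c2)cc1)C(F)(F)F` differs from compound 2 by trifluoromethyl in place of methyl on an aromatic carbon, the same kind of change, although here the place is not also ortho to a group of 9 heavy atoms. Among the compounds with values here, a step of comparable size is expected, a 10-fold higher number from compound 2 to compound 4 (1.00 log units; beyond the scatter), because the one measured example of this kind of change gave an at least 18-fold higher number from compound 1 to compound 3 (1.27 log units; beyond the scatter). Compound 4 is therefore estimated at 22000 nM, between 6000 nM and 60000 nM, and may itself end at a limit.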

Compound 4, half-maximal inhibitory concentration: > 30000 nM
Compound 4: only a limit was reported; the forecaster's own chance of this, stated with the estimate: 55%; middle value at least 1.3-fold (0.13 log units) away from the limit.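

In this assay, putting trifluoromethyl in place of methyl on an aromatic carbon again weakens inhibition, with an at least 13-fold higher number from compound 2 to compound 4 (1.13 log units; beyond the scatter). Compound 4 stands at a limit of this assay, > 30000 nM, and this is a limit, not a true number. The change therefore points the same way on both cores, but the data cannot show whether its size carries over from one core to the other: the same change on two cores in this assay, an at least 18-fold higher number (1.27 log units; beyond the scatter) from compound 1 to compound 3 and an at least 13-fold higher number (1.13 log units; beyond the scatter) from compound 2 to compound 4; the limit leaves it open whether they differ

On these data alone, how much weaker compound 3 and compound 4 really are stays open. So does whether a chlorine atom, an ethyl group or a methoxy group in the same place would keep inhibition close to that of compound 1 and compound 2.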